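A Triazolone Swap Tested Against Cytotoxicity in MT4 Cells

The source may report more compounds than this note shows. Statements on the series, on what has been measured and on what is new or still open speak of the compounds shown alone.

Measured compounds:
Compound 1 `Cc1cc(C)cc(S(=O)(=O)c2c(C(=O)NC3CC4(CCN(CC(N)=O)C4)C3)[nH]c3ccc(Cl)cc23)c1`: 3700 nM
Compound 2 `Cc1cc(C)cc(S(=O)(=O)c2c(C(=O)NC3CC4(C3)CN(CC(N)=O)C4)[nH]c3ccc(Cl)cc23)c1`: 6080 nM
Compound 3 `Cc1cc(C)cc(S(=O)(=O)c2c(C(=O)NC3CC4(C3)CN(Cc3n[nH]c(=O)n3C)C4)[nH]c3ccc(Cl)cc23)c1`: 65600 nM

In a toxicity assay on MT4 cells (Homo sapiens) for cytotoxicity, read by MTT assay, with a stated time of 7 days (a higher number here means that more compound is tolerated, a lower number that less compound is tolerated), compound 1 gives 3700 nM and compound 2 gives 6080 nM, and the step of a 1.6-fold higher number from compound 1 to compound 2 (0.22 log units; within the scatter) is small. The two cores differ as follows: a group of 12 heavy atoms (9 carbon, 2 nitrogen, 1 oxygen; one four-membered non-aromatic ring of carbon only, one five-membered non-aromatic ring with 1 hetero atom) in place of a group of 11 heavy atoms (8 carbon, 2 nitrogen, 1 oxygen; one four-membered non-aromatic ring of carbon only, one four-membered non-aromatic ring with 1 hetero atom), on an amide-type nitrogen. Compound 3 `Cc1cc(C)cc(S(=O)(=O)c2c(C(=O)NC3CC4(C3)CN(Cc3n[nH]c(=O)n3C)C4)[nH]c3ccc(Cl)cc23)c1` gives 65600 nM in this assay, so the step of an 11-fold higher number from compound 2 to compound 3 (1.03 log units; beyond the scatter) is large; the change made there is a group of 7 heavy atoms (3 carbon, 3 nitrogen, 1 oxygen; one five-membered aromatic ring with 3 hetero atoms) in place of a group of 3 heavy atoms (1 carbon, 1 nitrogen, 1 oxygen; no ring), on a saturated chain carbon bound to an amine nitrogen in a ring.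

Compound 4 `Cc1cc(C)cc(S(=O)(=O)c2c(C(=O)NC3CC4(CCN(Cc5n[nH]c(=O)n5C)C4)C3)[nH]c3ccc(Cl)cc23)c1` carries the same change on the core of compound 1: a group of 7 heavy atoms (3 carbon, 3 nitrogen, 1 oxygen; one five-membered aromatic ring with 3 hetero atoms) in place of a group of 3 heavy atoms (1 carbon, 1 nitrogen, 1 oxygen; no ring), on a saturated chain carbon bound to an amine nitrogen in a ring. Among the measured compounds shown here, since compound 1 and compound 2 lie within the scatter of each other, the same step is expected for compound 4, namely an 11-fold higher number from compound 1 to compound 4 (1.03 log units; beyond the scatter), because an 11-fold higher number from compound 2 to compound 3 (1.03 log units; beyond the scatter) is the only measured instance of this change. Compound 4 is therefore estimated at 40000 nM in this assay, expected between 15000 nM and 110000 nM.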

Compound 4, half-maximal cytotoxic concentration: > 214000 nM
Compound 4: no number, only a limit; the forecaster's own chance of this, stated with the estimate: 10%; middle value at least 5.3-fold (0.72 log units) from the limit.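

On the core of compound 1, replacing carbamoyl with the five-membered aromatic ring group gives an at least 57-fold higher number from compound 1 to compound 4 (1.76 log units; beyond the scatter) in this assay. The direction of the step carries over from one core to the other, but its size does not: the same change on two cores in this assay, an 11-fold higher number (1.03 log units; beyond the scatter) from compound 2 to compound 3 and an at least 57-fold higher number (1.76 log units; beyond the scatter) from compound 1 to compound 4, at least 5.3-fold (0.72 log units) apart, beyond the scatter of two such steps. On these data alone, the value for compound 4 is a limit and not a number, so the full size of its step stays unknown, and two cores alone set no rule for the series: the limit of > 214000 nM in this assay, at which 1 of the 4 values shown sits.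

The compounds shown leave open whether a carboxylic acid or an amine on the same saturated chain carbon would also differ between the two cores. They also leave open how this change would behave on any third core.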